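Swapping the aryl group on the sulfonyl: compound 3 to 4

The source may report more compounds than this note shows. Statements on the series, on what has been measured and on what is new or still open speak of the compounds shown alone.

Measured so far:
Compound 1, `Cc1ccccc1S(=O)(=O)N1CCN(c2cnc(C(=O)NCc3ccc(F)cc3)cn2)CC1`, gives 0.95.
Compound 2, `O=C(NCc1ccccc1)c1ccc(N2CCC(S(=O)(=O)c3cccc(Cl)c3Cl)CC2)nn1`, gives 0.75.
Compound 3, `O=C(NCc1ccc(F)cc1)c1ccc(N2CCN(S(=O)(=O)c3ccccc3C(F)(F)F)CC2)nn1`, gives 0.66.

These three compounds were tested in an ADME assay on microsomes from liver (Mus musculus), read by LC-MS, using NADPH, tested at 10 uM; a higher number here means that the liver removes a larger share of the compound in one pass, a lower number that the liver removes a smaller share. Compound 3 shows the lowest of the three numbers. Its nearest neighbour is compound 2, whose value sits higher but within the usual scatter, so the two cannot be told apart. Compound 1 lies furthest away, beyond the scatter. Among the compounds with values here, none of these pairs differ in only one place, so no single step between them is known.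

Compound 4, `Cc1ccc(F)cc1S(=O)(=O)N1CCN(c2ccc(C(=O)NCc3ccc(F)cc3)nn2)CC1`, has not yet been measured. It differs from compound 3 in one place: 5-fluoro-2-methylphenyl in place of 2-(trifluoromethyl)phenyl on a sulfonyl sulfur. Within the data shown here, with no measured step of this kind to lean on, the expectation in this assay is a small rise from compound 3, of a size that may not exceed the scatter. For compound 4 the estimated value is 0.75, with a range from 0.55 to 0.92, and the expected step is a number 0.090 higher from compound 3 to compound 4 (within the scatter).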

Compound 4, hepatic extraction ratio: 0.47
Compound 4: middle estimate off by 0.28, on the high side; measured number outside the range, below it.
By their numbers in this assay, from the lowest: compound 4; then compounds 3 and 2 (each within the scatter of the next); then compound 1.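

In this assay the swap to 5-fluoro-2-methylphenyl in place of 2-(trifluoromethyl)phenyl gives a number 0.19 lower from compound 3 to compound 4 (beyond the scatter) and is the only change in one place among the compounds shown. The earlier compounds shown here differ from one another in more than one place, so they could not show that the aryl group on this sulfonyl sulfur, on its own, can move the number beyond the scatter. No measurement shown here accounts for the direction or size of this step.

This single swap changes the aryl group in more than one way, so the compounds shown do not reveal which part of it matters. They also leave open how a plain phenyl or a pyridine ring on the same sulfonyl sulfur would behave in this series.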